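4-Fluorobenzyl to 4-bromobenzyl in compound 3

The source may report more compounds than this note shows. Statements on the series, on what has been measured and on what is new or still open speak of the compounds shown alone.

In a functional assay, read by spectrophotometry, with a stated time of 30 min (on this read-out higher numbers stand for weaker inhibition and lower numbers for stronger inhibition), compound 1 (`Cc1ccc(CN2CCC(CCNC(=O)/C=C/c3cc(C(C)(C)C)c(O)c(C(C)(C)C)c3)CC2)cc1`) gives 60400 nM, compound 2 (`CC(C)(C)c1cc(/C=C/C(=O)NCCC2CCN(Cc3ccccc3F)CC2)cc(C(C)(C)C)c1O`) gives 55900 nM and compound 3 (`CC(C)(C)c1cc(/C=C/C(=O)NCCC2CCN(Cc3ccc(F)cc3)CC2)cc(C(C)(C)C)c1O`) gives 57500 nM. Compound 3 therefore stands level with the other two, as all three values lie within the scatter of one another.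

Compound 4 (`CC(C)(C)c1cc(/C=C/C(=O)NCCC2CCN(Cc3ccc(Br)cc3)CC2)cc(C(C)(C)C)c1O`) carries bromo in place of fluoro on an aromatic carbon, para to a large group: bromo in place of fluoro on an aromatic carbon.

Among the measured compounds shown here, the closest precedent is the exchange of fluoro for methyl at that place, a 1.1-fold lower number from compound 1 to compound 3 (0.02 log units; within the scatter). Moving to the 2-fluorophenyl arrangement and back gives a 1.1-fold lower number from compound 1 to compound 2 (0.03 log units; within the scatter) and a 1.0-fold higher number from compound 2 to compound 3 (0.01 log units; within the scatter). For the measured compounds named here, all three steps lie within the scatter, but no bromo compound has been measured, so this precedent is limited to three compounds.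

No change beyond the scatter is expected, and the expected step is a 1.1-fold lower number from compound 3 to compound 4 (0.04 log units; within the scatter). For compound 4 the estimated value is 52000 nM, with an expected range of 28000 nM to 85000 nM.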

Compound 4, half-maximal inhibitory concentration: 85600 nM
The estimate for compound 4 lay 1.6-fold (0.22 log units) below the measured number, and the stated range ends below it.
By their numbers in this assay, from the lowest: compounds 2, 3, 1 and 4 (each within the scatter of the next).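

In this assay, bromo in place of fluoro on the aromatic carbon para to a large group gives a 1.5-fold higher number from compound 3 to compound 4 (0.17 log units; within the scatter), while the other two comparisons give a 1.5-fold higher number from compound 2 to compound 4 (0.19 log units; within the scatter) and a 1.4-fold higher number from compound 1 to compound 4 (0.15 log units; within the scatter). Among the compounds shown here, the range of substituents tolerated without a step beyond the scatter now extends to bromo, whereas the earlier compounds showed this only for methyl and fluoro, so none of the four substituent patterns is separated from another at this position. No accompanying measurement speaks to the reason for this flat picture.

Going by these compounds, whether an amine, a carboxylic acid or a methoxy group on this aromatic carbon would give a step beyond the scatter remains open. Also open, on these data alone, is whether a change elsewhere on the shared core would move the number more than any change at this position has.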